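Shortening the Acid Chain of Compound 2

The compounds below may be only part of what the source reports. "The series", "measured", "known", "first", "only" and "open" are said of these compounds alone.

For the measured compounds named here, compound 2 `Cc1c(CCCCC(=O)O)c2ccccc2n1Cc1ccc(O)c(C(C)C)c1` holds the lower of the two numbers measured so far in an assay on CV-1 cells for agonist activity at thyroid hormone receptor beta (Homo sapiens), read by reporter gene assay, with a stated time of 10 h (on this read-out lower numbers stand for an effect already at smaller amounts and higher numbers for an effect only at larger amounts of compound), where compound 2 gives 62 nM. Compound 1 `Cc1cc2c(NC(=O)CC(=O)O)cccc2n1Cc1ccc(O)c(C(C)C)c1`, which carries its acid on a different arm of the shared core, gives 1700 nM in this assay, a higher number that lies beyond the usual scatter. Compound 3 `Cc1c(CCC(=O)O)c2ccccc2n1Cc1ccc(O)c(C(C)C)c1` keeps the core and the phenol of compound 2 and differs from it only in the acid chain: carboxy in place of 2-carboxyethyl on a saturated chain carbon, two bonds along the chain from an aromatic carbon. Going by the values given here, no measured pair shows a shortening of this kind, so the size of the step cannot be read from the data. A modest shift is expected, a 1.5-fold higher number from compound 2 to compound 3 (0.16 log units; within the scatter), not clearly beyond the scatter in either direction. Compound 3 is therefore estimated at 90 nM in this assay, within a range from 20 nM to 400 nM.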

Compound 3, half-maximal effective concentration: 37 nM
Estimate against measurement, compound 3: 2.4-fold (0.39 log units) above; the range from low to high includes it.
By their numbers in this assay, from the lowest: compounds 3 and 2 (each within the scatter of the next); then compound 1.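

For the compounds shown here, the pair of compound 2 and compound 3 is the first in which only the acid chain differs, with the rest of the shared core and the phenol held constant. In this assay the exchange of 2-carboxyethyl for carboxy on a saturated chain carbon, two bonds along the chain from an aromatic carbon, gives a 1.7-fold lower number from compound 2 to compound 3 (0.22 log units; within the scatter) and so does not separate the two compounds. Read on the whole arm, 4-carboxybutyl and 2-carboxyethyl are not told apart here, and no measured property bears on this result.

A single pair cannot show how the number depends on chain length at this position. Going by these compounds, whether carboxymethyl on the same carbon, or a longer chain than 4-carboxybutyl, would fall within the scatter of these two compounds stays open, as does the effect of an amide in place of the carboxylic acid.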